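The source may hold more compounds than are shown below. What is called first, only, known or untested is meant among the compounds shown, and "the series" means these compounds.

Compound 2 `CC1(C)Cc2c(sc(NC(=O)c3cc(C(F)(F)F)n[nH]3)c2C(N)=O)C(C)(C)O1` carries a 3-(trifluoromethyl)-1H-pyrazol-5-yl group on the carbonyl carbon of its amide. In an assay on cells for positive allosteric modulation of Cystic fibrosis transmembrane conductance regulator variant G551D (Homo sapiens), with stated times of 10 min and 2 min, in the presence of a further agent that is not named here (a higher number here means that more compound is needed for the effect, a lower number that less compound is needed), compound 2 gives 130 nM. Going by the values given here, the only companion is compound 1 `Cc1cn[nH]c1C(=O)Nc1sc2c(c1C(N)=O)CC(C)(C)OC2(C)C`, which carries 4-methyl-1H-pyrazol-5-yl at the same place; in this assay compound 1 gives 123 nM. The two numbers are indistinguishable: a 1.1-fold higher number from compound 1 to compound 2 (0.02 log units; within the scatter).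

Compound 3 `Cc1n[nH]c(C(=O)Nc2sc3c(c2C(N)=O)CC(C)(C)OC3(C)C)c1Cl` has not been measured. Its change from compound 2 is a group of 7 heavy atoms (4 carbon, 2 nitrogen, 1 chlorine; one five-membered aromatic ring with 2 hetero atoms) in place of a group of 9 heavy atoms (4 carbon, 2 nitrogen, 3 fluorine; one five-membered aromatic ring with 2 hetero atoms), on a carbonyl carbon, so the amide and the shared core remain untouched and only the substituents on the five-membered aromatic ring with 2 hetero atoms are exchanged. Among the compounds with values here, the one measured step that speaks to this kind of swap, a 1.1-fold higher number from compound 1 to compound 2 (0.02 log units; within the scatter), shows that changing the substituents on that ring left the number essentially where it was. Nothing in the data points to a different outcome for a chlorine and a methyl group in place of the trifluoromethyl group. The expectation for compound 3 is therefore no step beyond the scatter, a 1.0-fold lower number from compound 2 to compound 3 (0.02 log units; within the scatter), and its estimated value in this assay is 125 nM, within a range of 55 nM to 280 nM.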

Compound 3, half-maximal effective concentration: 199 nM
The estimate for compound 3 lay 1.6-fold (0.20 log units) below the measured number; low and high end bracket the measured number.
By their numbers in this assay, from the lowest: compounds 1, 2 and 3 (each within the scatter of the next).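

Compound 3 adds a third substituent pattern on the five-membered aromatic ring, now with chlorine and a methyl group together, and in this assay the number still does not leave the scatter: a 1.5-fold higher number from compound 2 to compound 3 (0.18 log units; within the scatter), and a 1.6-fold higher number from compound 1 to compound 3 (0.21 log units; within the scatter). Across the three compounds, then, a methyl group alone, a trifluoromethyl group alone, and chlorine with methyl cannot be told apart in this assay, so the data show a tolerance for these exchanges at this place on the carbonyl carbon and give no ranking among them. Nothing available here gives any measured property that bears on this result, so the data offer no account of why these groups behave alike.

The compounds shown leave open whether this tolerance extends to quite different groups on the ring, such as an amine, a carboxylic acid or a longer chain like butyl. They also leave open what happens when the five-membered ring itself is exchanged, for example for a phenyl ring on the same carbonyl carbon.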